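Swapping cyano for trifluoromethoxy in a cytotoxic series

The source may report more compounds than this note shows. Statements on the series, on what has been measured and on what is new or still open speak of the compounds shown alone.

In a functional assay on Jurkat cells (Homo sapiens) for cytotoxicity, read by luminescence and CellTiter-Glo, with a stated time of 3 days (on this read-out higher numbers stand for weaker inhibition and lower numbers for stronger inhibition), compound 1 (`N#Cc1ccc(NC(=O)c2cc(Cl)ccc2O)c(Cl)c1`) gives 620 nM as its value. Compound 2 (`N#Cc1ccc(NC(=O)c2ccc(Br)cc2O)cc1Cl`) gives 750 nM and compound 3 (`O=C(Nc1cc(C(F)(F)F)cc(C(F)(F)F)c1)c1cc(Br)c(F)cc1O`) gives 700 nM in the same test. These three numbers lie within the scatter of one another, so compound 1 stands level with the other two and no ranking can be drawn. No two of them differ in just one place, so no single change can be read from them.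

Compound 4 (`O=C(Nc1ccc(OC(F)(F)F)cc1Cl)c1cc(Cl)ccc1O`) has yet to be measured. It has trifluoromethoxy in place of cyano on an aromatic carbon of the core of compound 1 (trifluoromethoxy in place of cyano on an aromatic carbon), at a place meta to a chloro group and para to a large group. Compound 3 has no cyano group and still gives 700 nM here, which suggests that losing the cyano need not change much. The estimated step is a 1.1-fold lower number from compound 1 to compound 4 (0.05 log units; within the scatter) in this assay and is expected to stay within the scatter. For compound 4 the expected value is 550 nM with an estimated range from 220 nM to 1400 nM in this test.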

Compound 4, half-maximal inhibitory concentration: 880 nM
Beside the measured number, compound 4's estimate is 1.6-fold (0.20 log units) below it; the measured number falls inside the stated range.
By their numbers in this assay, from the lowest: compounds 1, 3, 2 and 4 (each within the scatter of the next).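

In this assay, putting trifluoromethoxy in place of cyano on an aromatic carbon gives a 1.4-fold higher number from compound 1 to compound 4 (0.15 log units; within the scatter) on the shared core. Among these compounds, compound 1 and compound 4 are the first pair here that differ in one place, so this change can now be read on its own rather than inferred from compounds that differ in several places. At this place, meta to a chloro group and para to a large group, a group of 5 heavy atoms replaces one of 2 with a step that stays within the scatter, but no measurement here explains why.

Going by these compounds, it remains open whether an amine or a carboxylic acid at this place would also stay within the scatter of compound 1. On these data alone, it is also open whether the same swap on compound 2, which also carries cyano, would give a step of similar size.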